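A few compounds are considered here, and "the series" means these few. Any claim that something is new, unique, unknown or untested is made for them only; others in the source may bear on it.

Measured compounds in the series:

compound 1 `COc1cccc(CC/C=C(\C)CCC=C(C)C)c1` — > 100000 nM in an ADME assay on HepG2 cells (Homo sapiens) for cytotoxicity, read by MTT assay, with a stated time of 24 h; a lower number here means that less compound is tolerated, a higher number that more compound is tolerated
compound 2 `COc1ccc(CC(O)C2=C(C)CCCC2(C)C)cc1` — > 100000 nM

Both values given so far are limits of this assay, not numbers. Compound 2 stands at the limit of > 100000 nM in this assay, at which 2 of the 2 values shown sit, so nothing separates it from compound 1 on the numbers shown; both simply report that the tested range was tolerated without reaching a half-maximal effect. Going by the values given here, no step between measured compounds is available, and the two structures differ in more than one place, so no single change can be read from them.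

Compound 3 `CC1=C(C(O)Cc2ccc(C(C)C)cc2)C(C)(C)CCC1` is the next compound to go into this assay. It differs from compound 2 by isopropyl in place of methoxy on an aromatic carbon. Among the compounds with values here, with both measured compounds sitting at the limit, there is no measured step to lean on for direction or size; the expectation for compound 3 is therefore a step that the limit leaves unreadable from compound 2 to compound 3 of no size beyond the usual scatter, most likely another limit value. Compound 3 is expected at 150000 nM, within a range of 50000 nM to 400000 nM.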

Compound 3, half-maximal cytotoxic concentration: > 100000 nM
Compound 3 gave a limit, no number; the forecaster's own chance of this, stated with the estimate: 70%; the middle value is on the limit's open side.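

Compound 2 and compound 3 both give limits in this assay, not numbers, so isopropyl in place of methoxy on an aromatic carbon yields no readable step: the limit of > 100000 nM in this assay, at which 3 of the 3 values shown sit.

The compounds shown leave open how far the concentration tolerated in this assay extends for any of them, and whether any single change alters it.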